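This account rests on a few compounds, and the source may have more. Where it says the series, first, only, none or still open, it means among the compounds named here.

The measured compounds:

Compound 1, `CCC(C(=O)N1CCN(c2cccc(F)c2)CC1)N1C(=O)CCC1=O`, gives 0% in a functional assay on the whole organism (strain Swiss) with Mus musculus as the target, in the maximal electroshock model, with a stated time of 0.25 h, at a dose of 100 mg/kg by the intraperitoneal route; a higher number here means a stronger effect of the compound at the dose given, a lower number a weaker effect.
Compound 2, `CCC(C(=O)N1CCN(c2ccccc2F)CC1)N1C(=O)CCC1=O`, gives 0% in this assay.
Compound 3, `CCC(C(=O)N1CCN(c2cccc(C(F)(F)F)c2)CC1)N1C(=O)CCC1=O`, gives 75% in this assay.

Compound 3 stands highest of the three in this assay, and both of its steps to the others lie beyond the scatter. Moving the fluoro around the ring did nothing: no change at the digits printed from compound 1 to compound 2 (within the scatter). Exchanging it brought the whole gain: a number 75 percentage points higher from compound 1 to compound 3 (beyond the scatter).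

Compound 4, `CCC(C(=O)N1CCN(c2ccccc2)CC1)N1C(=O)CCC1=O`, differs from compound 3 in one place: hydrogen in place of trifluoromethyl on an aromatic carbon. Among the measured compounds shown here, the only measured step that bears on this change is a number 75 percentage points higher from compound 1 to compound 3 (beyond the scatter), which shows how much came with trifluoromethyl in place of fluoro on an aromatic carbon. For the measured compounds named here, with trifluoromethyl removed and nothing but hydrogen left, a large drop is expected, though no measured compound carries hydrogen at this place, so the size of the fall is uncertain. Compound 4 is therefore estimated to give 15% in this assay, with an expected range from 0% to 50%. That estimate corresponds to an expected step of a number 60 percentage points lower from compound 3 to compound 4 (beyond the scatter).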

Compound 4, a percentage reported as activity, at one dose (the size of the read-out at that dose, not a potency): 25%
Beside the measured number, compound 4's estimate is 10 percentage points below it; measured number inside the range.
By their numbers in this assay, from the lowest: compounds 1 and 2 (each within the scatter of the next); then compound 4; then compound 3.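

In this assay, among the compounds shown here, hydrogen on this aromatic carbon supplies the reference point that the earlier compounds lacked. Trifluoromethyl stands above that reference, with a number 50 percentage points lower from compound 3 to compound 4 (beyond the scatter) when the group leaves, whereas the fluoro compounds stand below it, with a number 25 percentage points higher from compound 1 to compound 4 (beyond the scatter) and a number 25 percentage points higher from compound 2 to compound 4 (beyond the scatter) when fluoro leaves. Replacing hydrogen on the ring therefore does not move the number in one direction across these four compounds, and nothing measured here offers an explanation for that split.

From the compounds shown here alone, how chloro, methyl or methoxy in place of hydrogen would compare remains open. So does whether the gain over hydrogen belongs to trifluoromethyl alone or extends to a larger group such as pentafluoroethyl.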